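The source may hold more compounds than are shown below. What is called first, only, known or untested is meant among the compounds shown, and "the series" means these compounds.

Measured so far in an assay for inhibition of Rho-associated protein kinase 1 (Homo sapiens), read by TR-FRET, with stated times of 5 min and 2 h; a lower number here means a stronger inhibitor, a higher number a weaker inhibitor:
compound 1 `O=c1[nH]c(CN2CCCC2)nc2cc(-c3ccncc3)sc12` — 180 nM
compound 2 `O=c1[nH]c(CN2CCCC2)nc2cc(-c3cn[nH]c3)sc12` — 820 nM

Compound 2 gives the highest of the two numbers in this assay; its nearest neighbour is compound 1, and the step of a 4.6-fold higher number from compound 1 to compound 2 (0.66 log units; beyond the scatter) lies beyond the scatter. Compound 3 `CCc1n[nH]cc1-c1cc2nc(CN3CCCC3)[nH]c(=O)c2s1` is not yet measured. It differs from compound 2 by ethyl in place of hydrogen on an aromatic carbon, placed next to the ring nitrogen of the five-membered ring, so that the substituent reads 3-ethyl-1H-pyrazol-4-yl in place of 1H-pyrazol-4-yl. Among the compounds with values here, the only measured step, that from compound 1 to compound 2, exchanges one ring for another and does not bear on adding an ethyl group to a ring that is kept. Nothing in the two measured compounds therefore points in either direction, and no step beyond the scatter is expected: a 1.2-fold lower number from compound 2 to compound 3 (0.07 log units; within the scatter) is the estimated change. For compound 3 the expected value in this assay is 700 nM, estimated to fall between 250 nM and 2000 nM.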

Compound 3, half-maximal inhibitory concentration: 830 nM
For compound 3 the middle estimate is 1.2-fold (0.07 log units) below the measured one; measured number inside the range.
By their numbers in this assay, from the lowest: compound 1; then compounds 2 and 3 (each within the scatter of the next).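

In this assay, ethyl in place of hydrogen on the aromatic carbon next to the ring nitrogen gives no change beyond the scatter, a 1.0-fold higher number from compound 2 to compound 3 (0.01 log units; within the scatter), so this position accepts ethyl with the number held, something the earlier ring exchange could not show. The 3-ethyl-1H-pyrazol-4-yl group also does not close the distance to pyridin-4-yl, with a 4.6-fold higher number from compound 1 to compound 3 (0.66 log units; beyond the scatter) remaining beyond the scatter. No measurement here bears on why the ethyl group leaves the number where it is.

Open, as far as these compounds go, is whether a longer chain such as butyl, a primary amine or a carboxylic acid on this same carbon would also leave the number unchanged. Also open, from the compounds shown here alone, is whether ethyl on the pyridin-4-yl ring of compound 1 would do the same.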